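The source may hold more compounds than are shown below. What is called first, only, known or untested is meant among the compounds shown, and "the series" means these compounds.

Compound 1, `Nc1ncnn2c([C@@H]3O[C@H](CO)[C@@H](O)[C@H]3O)cc(C#CC3CC3)c12`: 50 nM
Compound 2, `Nc1ncnn2c([C@@H]3O[C@H](CO)[C@@H](O)[C@H]3O)cc(-c3ccccc3)c12`: 82600 nM
Compound 3, `Nc1ncnn2c([C@@H]3O[C@H](CO)[C@@H](O)[C@H]3O)cc(-c3ccccc3F)c12`: > 100000 nM

Compound 1 carries a 2-cyclopropylethynyl group on the aromatic carbon of the shared core and gives 50 nM in a functional assay on HCT-116 cells (Homo sapiens) for antiproliferative activity, with a stated time of 72 h; a lower number here means a stronger inhibitor, a higher number a weaker inhibitor. Compound 2 carries phenyl at that carbon and gives 82600 nM; the step is a 1700-fold higher number from compound 1 to compound 2 (3.22 log units; beyond the scatter). For compound 3, which carries 2-fluorophenyl, the result in this assay is a limit of the assay and not a number: > 100000 nM, at the limit of > 100000 nM in this assay, at which 1 of the 3 values shown sits. The step of an at least 2000-fold higher number from compound 1 to compound 3 (3.30 log units; beyond the scatter) is likewise large. Between compound 2 and compound 3 the step of an at least 1.2-fold higher number from compound 2 to compound 3 (0.08 log units; that floor lies within the scatter) stays within the scatter, so compound 3 stands at the weak end of the set, defined only by that limit.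

Compound 4, `Nc1ncnn2c([C@@H]3O[C@H](CO)[C@@H](O)[C@H]3O)cc(-c3ccsc3)c12`, differs from compound 3 in one place: thiophen-3-yl in place of 2-fluorophenyl on an aromatic carbon. For the measured compounds named here, the steps that bear on it are the two aryl replacements, a 1700-fold higher number from compound 1 to compound 2 (3.22 log units; beyond the scatter) and an at least 2000-fold higher number from compound 1 to compound 3 (3.30 log units; beyond the scatter), both large and both upward; the step of an at least 1.2-fold higher number from compound 2 to compound 3 (0.08 log units; that floor lies within the scatter) between the two aryl compounds is small. Since thiophen-3-yl is again an aromatic ring at the same carbon, no step beyond the scatter in this assay is expected from compound 3 to compound 4. Compound 4 is therefore estimated at 90000 nM, between 20000 nM and 300000 nM. The expected step is an at least 1.1-fold lower number from compound 3 to compound 4 (0.04 log units; that floor lies within the scatter).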

Compound 4, half-maximal inhibitory concentration: 45200 nM
The estimate for compound 4 lay 2.0-fold (0.30 log units) above the measured number, within the range that was stated.
By their numbers in this assay, from the lowest: compound 1; then compounds 4 and 2 (each within the scatter of the next). At a limit, above all of these: compound 3.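

In this assay, the five-membered aromatic ring of thiophen-3-yl does not restore what the 2-cyclopropylethynyl group gives at this carbon, as the step shows: a 900-fold higher number from compound 1 to compound 4 (2.96 log units; beyond the scatter). So the large loss seen with phenyl and 2-fluorophenyl also holds for an aromatic ring with a hetero atom, and replacing the six-membered carbon ring of phenyl with thiophen-3-yl gives no readable change: a 1.8-fold lower number from compound 2 to compound 4 (0.26 log units; within the scatter). The step from 2-fluorophenyl is beyond the scatter, an at least 2.2-fold lower number from compound 3 to compound 4 (0.34 log units; beyond the scatter), but it is only a floor, since compound 3 is known only by a limit of the assay: the limit of > 100000 nM in this assay, at which 1 of the 4 values shown sits.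

With only aromatic rings to set against compound 1, the compounds shown leave open whether the activity at this carbon depends on the triple bond, on the cyclopropyl end or on both. From the compounds shown here alone, it also remains open whether an ethynyl group carrying a longer chain or an amine, or a plain alkyl chain without the triple bond, would stay near compound 1 or fall with the aromatic rings.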